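Adding a nitro group to compound 3

A few compounds are considered here, and "the series" means these few. Any claim that something is new, unique, unknown or untested is made for them only; others in the source may bear on it.

Measured so far:
compound 1 `C/C(=N\NC(=S)Nc1cccc(F)c1)c1ccccn1`: 18 nM
compound 2 `C/C(=N\NC(=S)Nc1ccccc1Cl)c1ccccn1`: 2.6 nM
compound 3 `C/C(=N\NC(=S)Nc1ccccc1)c1ccccn1`: 1.4 nM

These values come from a functional assay on U-87MG ATCC cells (Homo sapiens) for cytotoxicity, read by MTT assay, with a stated time of 48 h; a lower number here means a stronger inhibitor, a higher number a weaker inhibitor. Compound 3 gives 1.4 nM, which lies within the scatter of compound 2 at 2.6 nM. Compound 1 stands clearly apart at 18 nM.

The next compound, compound 4 `C/C(=N\NC(=S)Nc1ccc([N+](=O)[O-])cc1)c1ccccn1`, has nitro in place of hydrogen on an aromatic carbon, para to a large group: nitro in place of hydrogen on an aromatic carbon.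

For the measured compounds named here, two measured steps bear on this change, since each replaces a halogen with hydrogen. Fluoro to hydrogen is large, a 13-fold lower number from compound 1 to compound 3 (1.11 log units; beyond the scatter). Chloro to hydrogen stays within the scatter, a 1.9-fold lower number from compound 2 to compound 3 (0.27 log units; within the scatter). Read in reverse, neither shows a substituent lowering the number, but neither involves nitro, so this guide is loose.

A moderately higher number is therefore expected in this assay, a 4.3-fold higher number from compound 3 to compound 4 (0.63 log units; beyond the scatter). The estimated value for compound 4 is 6 nM, with an expected range from 1.2 nM to 30 nM.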

Compound 4, half-maximal inhibitory concentration: 160 nM
The estimate for compound 4 lay 27-fold (1.43 log units) below the measured number; the measured number lies above the stated range.
By their numbers in this assay, from the lowest: compounds 3 and 2 (each within the scatter of the next); then compound 1; then compound 4.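

In this assay, for the compounds shown here, placing nitro on the aromatic carbon para to a large group gives a 110-fold higher number from compound 3 to compound 4 (2.06 log units; beyond the scatter), a step that the earlier compounds could not foretell, as they only traded a halogen for hydrogen. It shows that this carbon does not accept every group: a single substituent of three heavy atoms is enough to move the number far from that of compound 3. No measurement available here explains why the number rises so far.

Nitro is the only group shown at this carbon, so it remains open whether the loss belongs to nitro itself or would follow any group placed there. An amine, a methoxy group or a carboxylic acid at the same place would help separate these two readings.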